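Methyl in place of chloro in compound 3

The source may report more compounds than this note shows. Statements on the series, on what has been measured and on what is new or still open speak of the compounds shown alone.

In a functional assay on MCF7 cells (Homo sapiens) for antiproliferative activity, read by sulforhodamine B assay, with a stated time of 48 h (on this read-out lower numbers stand for stronger inhibition and higher numbers for weaker inhibition), compound 1 `O=C(CCCCCCN1C(=O)/C(=N\O)c2ccccc21)NO` gives 790 nM and compound 2 `O=C(CCCCCCN1C(=O)/C(=N\O)c2cc([N+](=O)[O-])ccc21)NO` gives 1340 nM while compound 3 `CO/N=C1/C(=O)N(CCCCCCC(=O)NO)c2ccc(Cl)cc21` gives 1560 nM on the same read-out. Compound 3 thus sits within the scatter of both other compounds. Compound 4 `CO/N=C1/C(=O)N(CCCCCCC(=O)NO)c2ccc(C)cc21` differs from it by one change (methyl in place of chloro on an aromatic carbon), methyl in place of chloro on an aromatic carbon. For the measured compounds named here, the only measured step at such a carbon is a 1.7-fold higher number from compound 1 to compound 2 (0.23 log units; within the scatter) for nitro in place of hydrogen, and it lies within the scatter. Going by the values given here, no measured pair exchanges chloro or methyl, so no step beyond the scatter is expected in this assay in either direction. The expected step is a 1.2-fold lower number from compound 3 to compound 4 (0.08 log units; within the scatter) and stays within the scatter. For compound 4 the estimate is 1300 nM and the expected range runs from 600 nM to 2800 nM on this read-out.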

Compound 4, half-maximal inhibitory concentration: 16700 nM
Compound 4: the middle estimate sits 13-fold (1.11 log units) below what was measured; the whole stated range lies below it.
By their numbers in this assay, from the lowest: compounds 1, 2 and 3 (each within the scatter of the next); then compound 4.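

In this assay, methyl in place of chloro on this aromatic carbon gives an 11-fold higher number from compound 3 to compound 4 (1.03 log units; beyond the scatter), so a swap of one heavy atom for one heavy atom, with no hydrogen-bond donors or acceptors on either side, can move this read-out beyond the scatter. The earlier step at an aromatic carbon, a 1.7-fold higher number from compound 1 to compound 2 (0.23 log units; within the scatter), gave no such sign. Nothing available explains the difference. The compounds shown leave open whether hydrogen, fluoro, methoxy or an amine on this carbon would track with compound 3 or compound 4.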